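Lengthening a side chain in a gastric inhibition series

The compounds below may be only part of what the source reports. "The series", "measured", "known", "first", "only" and "open" are said of these compounds alone.

Compound 1 `N#CCCn1nc(-c2ccccc2)ccc1=O` gives 10.1% in a functional assay on the whole organism (stomach) for inhibition, with Rattus norvegicus as the target, at a dose of 100 mg/kg by the intraduodenal route; on this read-out higher numbers stand for more inhibition at the one dose given (going by the name of the read-out) and lower numbers for less inhibition.
Compound 2 `C/N=C(/S)CCCCCn1nc(-c2ccccc2)ccc1=O` gives 92.3%.
Compound 3 `N=C(S)CCn1nc(-c2ccccc2)ccc1=O` gives 53.7%.

All three share one core and differ only in the group attached on a saturated chain carbon, two bonds along the chain from an aromatic nitrogen. Compound 3 stands second highest of the three: the step of a number 43.6 percentage points higher from compound 1 to compound 3 (beyond the scatter) lifts it well clear of compound 1, while the step of a number 38.6 percentage points lower from compound 2 to compound 3 (beyond the scatter) leaves it clearly beneath compound 2, and both gaps are beyond the usual scatter.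

Compound 4 `N=C(S)CCCCn1nc(-c2ccccc2)ccc1=O` is not yet measured. It differs from compound 3 by a group of 5 heavy atoms (3 carbon, 1 nitrogen, 1 sulfur; no ring) in place of a group of 3 heavy atoms (1 carbon, 1 nitrogen, 1 sulfur; no ring), on a saturated chain carbon, two bonds along the chain from an aromatic nitrogen. For the measured compounds named here, the steps that bear on this are those in which the group at this position grows: a number 82.2 percentage points higher from compound 1 to compound 2 (beyond the scatter) and a number 43.6 percentage points higher from compound 1 to compound 3 (beyond the scatter) both rise, and the larger group gave the larger rise, while a number 38.6 percentage points lower from compound 2 to compound 3 (beyond the scatter) falls as the group shrinks. A longer group is therefore expected to raise inhibition, though compound 4 lacks the part of compound 2 that sits on its nitrogen, so the rise is expected to stop short of compound 2.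

Compound 4 is therefore expected to show a step of a number 21.3 percentage points higher from compound 3 to compound 4 (beyond the scatter), giving an estimated 75%, with a range from 55% to 92%.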

Compound 4, a percentage reported as inhibition, in the whole organism at one dose (the size of the read-out at that dose, not a potency): 33.8%
For compound 4 the middle estimate is 41.2 percentage points above the measured one, and the stated range ends above it.
By their numbers in this assay, from the lowest: compound 1; then compound 4; then compound 3; then compound 2.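

In this assay, the group of 5 heavy atoms does not extend the rise expected from growth at this saturated chain carbon, as a number 19.9 percentage points lower from compound 3 to compound 4 (beyond the scatter) runs the opposite way, so a larger group here does not by itself bring more inhibition. It still beats the nitrile, with a number 23.7 percentage points higher from compound 1 to compound 4 (beyond the scatter), yet a number 58.5 percentage points lower from compound 2 to compound 4 (beyond the scatter) shows that it falls far short of compound 2, so across compound 3, compound 4 and compound 2 the numbers dip and then climb instead of following group size in a steady line. The data shown offer no explanation for this turn.

Compound 2 differs from compound 4 in both its longer chain and the methyl on its nitrogen, so the two changes remain unseparated, and compound 2's chain with an unsubstituted nitrogen, or compound 4's chain with that methyl, would tell them apart. Also open, from the compounds shown here alone, is how an amine or a carboxylic acid would read in place of this group at the same dose.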